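A few compounds are considered here, and "the series" means these few. Any claim that something is new, unique, unknown or untested is made for them only; others in the source may bear on it.

Of the compounds shown here, three have so far been measured in a functional assay on cells (Lymphocyte, Homo sapiens), read by trypan blue exclusion, with a stated time of 16 h, tested at 0.5 uM; on this read-out higher numbers stand for a stronger effect at the one concentration tested and lower numbers for a weaker effect. Compound 1 `CCCCCCCCCCCCCCCCc1c(C)c(N(C)C)nc(C)c1O` gives 75% in this assay. Compound 2 `CCCCCCCCCCCCCCCCCCCc1c(C)c(N(C)C)nc(C)c1O` gives 50% in this assay. Compound 3 `CCCCCCCCCCCCCCCCCCCc1nc(N(C)C)c(C)c(C)c1O` gives 38% in this assay, the lowest of the three numbers. Compound 2 and compound 3 are built from the same atoms joined differently; the difference between the two cores is not broken down here, and the two values alone show compound 3 standing lower than compound 2. Going from compound 2 to compound 1 the change is hydrogen in place of propyl on a saturated chain carbon, ten or more bonds along the chain from an aromatic carbon, and in this assay it gave a number 25 percentage points higher from compound 2 to compound 1 (beyond the scatter). Compound 4 `CCCCCCCCCCCCCCCCc1nc(N(C)C)c(C)c(C)c1O` awaits measurement in this assay; it arises from compound 3 by the same change, (hydrogen in place of propyl on a saturated chain carbon, ten or more bonds along the chain from an aromatic carbon), at the same place. This change appears twice among the compounds and has been seen once, so the expectation rests on that single step: the expected step is a number 22 percentage points higher from compound 3 to compound 4 (beyond the scatter), carried over from the earlier one because a number 25 percentage points higher from compound 2 to compound 1 (beyond the scatter). Compound 4 is therefore estimated at 60% in this assay, expected to lie between 44% and 78%.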

Compound 4, a percentage reported as activity, at one concentration (the size of the read-out at that concentration, not a potency): 91%
Compound 4: middle estimate off by 31 percentage points, on the low side, outside the stated range (above it).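

Going from the longer chain to the shorter one in this assay, the loss of propyl gave a number 53 percentage points higher from compound 3 to compound 4 (beyond the scatter), so the change pointed the same way on both cores, but its size did not carry over from one core to the other: the same change on two cores in this assay, a number 25 percentage points higher (beyond the scatter) from compound 2 to compound 1 and a number 53 percentage points higher (beyond the scatter) from compound 3 to compound 4, 28 percentage points apart, beyond the scatter of two such steps

The direction of the change therefore held on the two cores shown, whereas the earlier step alone would have understated its size on the core of compound 3. These two pairs do not show why the steps differ, nor whether the same direction would appear on any further core, and each value comes from one concentration and so says nothing about potency.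

The compounds shown leave open how a still shorter chain, or a chain ending in a carboxylic acid or an amine, would behave on either core. They also leave open whether replacing the dimethylamino group with a morpholine would change the gap seen here.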